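A few compounds are considered here, and "the series" means these few. Any claim that something is new, unique, unknown or untested is made for them only; others in the source may bear on it.

The measured compounds:
Compound 1, `CC(C)(C)CC(=O)Nc1cccc(C(=O)N2CCCC(C(=O)Nc3ccc(Cl)cc3)C2)c1`, gives 0% in an ADME assay on PC-3 cells (Homo sapiens) for cytotoxicity, read by WST assay, tested at 100 uM; on this read-out higher numbers stand for more inhibition at the one concentration tested (going by the name of the read-out) and lower numbers for less inhibition.
Compound 2, `O=C(Nc1ccc(Cl)cc1)C1CCCN(C(=O)c2cccc(-c3cccs3)c2)C1`, gives 4%.
Compound 3, `CSc1cccc(C(=O)N2CCCC(C(=O)Nc3ccc(Cl)cc3)C2)c1`, gives 0%.

Compound 3 stands level with compound 1 at the digits shown, the two together the lowest of the three numbers, while compound 2 sits only a little higher; all three values lie within the usual scatter of one another, so no order among them can be drawn. The steps of a number 4 percentage points higher from compound 1 to compound 2 (within the scatter), no change at the digits printed from compound 1 to compound 3 (within the scatter) and a number 4 percentage points lower from compound 2 to compound 3 (within the scatter) are each within the scatter.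

Compound 4, `O=C(c1ccccc1)c1cccc(C(=O)N2CCCC(C(=O)Nc3ccc(Cl)cc3)C2)c1`, has not yet been measured. It differs from compound 3 in one place: benzoyl in place of methylsulfanyl on an aromatic carbon. The group that enters, benzoyl, sits on an aromatic carbon of a six-membered aromatic ring of carbon only, meta to a large group. Among the compounds with values here, no measured step exchanges a group at this position for benzoyl; the nearest comparisons are the three measured steps at the same position, which run through (neopentylcarbonyl)amino, thiophen-2-yl and methylsulfanyl without any change beyond the scatter. The step of a number 3 percentage points higher from compound 3 to compound 4 (within the scatter) is therefore expected to stay within the scatter as well. The estimate for compound 4 in this assay is 3%, between 0% and 15%.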

Compound 4, a percentage reported as inhibition, at one concentration (the size of the read-out at that concentration, not a potency): 0%
The estimate for compound 4 lay 3 percentage points above the measured number, within the range that was stated.
By their numbers in this assay, from the lowest: compounds 1, 3, 4 and 2 (each within the scatter of the next).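

In this assay, benzoyl in place of methylsulfanyl on an aromatic carbon gives no change at the digits printed from compound 3 to compound 4 (within the scatter), and the exchanges for the other two groups give a number 4 percentage points lower from compound 2 to compound 4 (within the scatter) and no change at the digits printed from compound 1 to compound 4 (within the scatter). This place, meta to a large group, now holds a fourth group, and the exchange from methylsulfanyl with 2 heavy atoms and no ring to benzoyl with 8 heavy atoms and one six-membered aromatic ring of carbon only leaves the number within the scatter; across these four compounds, no group at this position stands apart from the others in this read-out. No further information bears on this result.

The compounds shown leave open whether an amine or a carboxylic acid on this aromatic carbon would give a number beyond the scatter of these four. They also leave open whether the same lack of separation would hold at other concentrations or with changes elsewhere in the shared core, since only this one position varies here and only one concentration is tested.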